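This account rests on a few compounds, and the source may have more. Where it says the series, first, only, none or still open, it means among the compounds named here.

Measured so far in a functional assay on A549 cells (Homo sapiens) for cytotoxicity, read by colorimetric assay and MTT assay; a lower number here means a stronger inhibitor, a higher number a weaker inhibitor:
compound 1 `COc1ccc(-c2cc3cccc(OC)c3nc2O)cc1` – 10000 nM
compound 2 `COc1ccc(-c2cc3c(OC)ccc(OC)c3nc2O)cc1` – 10000 nM
compound 3 `CCOC(=O)Cn1c(=O)c(-c2ccc(OC)cc2)cc2c(OC)cc(OC)cc21` – 10000 nM

Compound 3 stands level with compound 1 and compound 2 on these numbers, with nothing separating the three. Compound 4 `COc1ccc(-c2cc3c(OC)cc(OC)cc3n(CC(=O)O)c2=O)cc1` comes from compound 3 through (hydrogen in place of ethyl on an oxygen next to a carbonyl group), which reads as ethoxycarbonyl to carboxy. Among the measured compounds shown here, the only measured step, no change at the digits printed from compound 1 to compound 2 (within the scatter) for methoxy in place of hydrogen on an aromatic carbon, is a different change and bears on this one only loosely. For the measured compounds named here, no measured pair shows ethoxycarbonyl to carboxy, so the data give no direct guide to this step. In this assay the three compounds have shown no movement so far, and no step beyond the scatter is expected, in either direction. This expectation rests on very few compounds. The expected step is no change at the digits printed from compound 3 to compound 4 (within the scatter) on this reasoning. The estimate for compound 4 is 10000 nM with an expected range from 5000 nM to 20000 nM for the coming measurement.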

Compound 4, half-maximal inhibitory concentration: 10000 nM
For compound 4 middle estimate and measured number coincide at the digits printed; the range from low to high includes it.
By their numbers in this assay, from the lowest: compounds 1, 2, 3 and 4 (each within the scatter of the next).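

In this assay the change of ethoxycarbonyl to carboxy, with hydrogen in place of ethyl on an oxygen next to a carbonyl group, gives no change at the digits printed from compound 3 to compound 4 (within the scatter) and so leaves the read-out where it stood. Among the compounds shown here, this is the first measured pair to test this side chain, as the earlier step concerned only a methoxy on an aromatic carbon. At this position the ethyl can be removed without any shift at the digits printed, and no measurement on hand offers an explanation for this result.

Still open, from the compounds shown here alone, is whether an amine, a primary amide or a longer chain in place of carboxymethyl would move the number in this assay at all. The four compounds shown share one printed value, so they do not reveal which groups on the shared core, if any, can change it.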